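The source may report more compounds than this note shows. Statements on the series, on what has been measured and on what is new or still open speak of the compounds shown alone.

Of the compounds shown here, three built on a shared core have been measured in an ADME assay on Huh-7 cells (Homo sapiens) for cytotoxicity; on this read-out lower numbers stand for higher toxicity in this test and higher numbers for lower toxicity in this test. Compound 1 `CN1CCN(CCNCc2cn(-c3ccc([N+](=O)[O-])cc3)nc2-c2ccc(OC(F)(F)F)cc2)CC1` gives 4400 nM. Compound 2 `CN1CCN(CCNCc2cn(-c3ccc([N+](=O)[O-])cc3)nc2-c2ccc(C(F)(F)F)cc2)CC1` gives 3200 nM. Compound 3 `CCCN1CCC(CNCc2cn(-c3ccc(C(F)(F)F)cc3)nc2-c2ccc(Cl)cc2)CC1` gives 1900 nM. Going by the values given here, the one step between two compounds that differ in a single place, trifluoromethyl in place of trifluoromethoxy on an aromatic carbon, runs a 1.4-fold lower number from compound 1 to compound 2 (0.14 log units; within the scatter). Compound 2 stands second highest of the three numbers; its nearest is compound 1 and its furthest is compound 3, yet both gaps fall within the scatter, so the three compounds cannot be told apart on this read-out.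

Compound 4 `CN1CCN(CCNCc2cn(-c3ccc(F)cc3F)nc2-c2ccc(C(F)(F)F)cc2)CC1` has not yet been measured in this assay. It differs from compound 2 in one place: 2,4-difluorophenyl in place of 4-nitrophenyl on an aromatic nitrogen. Among the compounds with values here, no measured step bears on this change; the only step in hand concerns the other aromatic ring and stays within the scatter. Nothing in the data therefore points to a step beyond the scatter, and compound 4 is expected to give 3200 nM, with a range from 1400 nM to 7500 nM. This estimate means an expected step of no change at the digits printed from compound 2 to compound 4 (within the scatter), that is, nothing beyond the scatter.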

Compound 4, half-maximal cytotoxic concentration: 20000 nM
The estimate for compound 4 lay 6.3-fold (0.80 log units) below the measured number; the measured number lies above the stated range.
By their numbers in this assay, from the lowest: compounds 3, 2 and 1 (each within the scatter of the next, the first and the last beyond it); then compound 4.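

Going by these compounds alone, the change from 4-nitrophenyl to 2,4-difluorophenyl on the aromatic nitrogen gives a 6.3-fold higher number from compound 2 to compound 4 (0.80 log units; beyond the scatter) in this assay and is the first step to pass beyond the scatter, running towards lower toxicity in this test. Within the data shown here, it shows that this aryl group can move the read-out, whereas the single earlier step, a change on the other aromatic ring, stayed within the scatter, and that the three earlier compounds, which all sit well under compound 4, did not mark the top of the range for this series. No measurement on hand speaks to what lies behind the step.

The compounds shown leave open whether the step comes from the departure of the 4-nitrophenyl group or from the arrival of the two fluorine atoms, a question that a plain phenyl, a 4-fluorophenyl or a 4-cyanophenyl on that same nitrogen would help to settle. As far as these compounds go, it also remains open whether the same change would give a step of similar size with trifluoromethoxy on the other aromatic ring, or with the propylpiperidine side chain of compound 3.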